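The source may hold more compounds than are shown below. What is called first, only, known or untested is meant among the compounds shown, and "the series" means these compounds.

Measured so far in an ADME assay on L1210/0 cells (Mus musculus) for cytotoxicity, with a stated time of 48 h; on this read-out higher numbers stand for weaker inhibition and lower numbers for stronger inhibition:
- compound 1 `O=c1[nH]c(=O)n([C@H]2C[C@H](O)[C@@H](CO)O2)cc1/C=C/I` gives 63900 nM
- compound 2 `N#CSc1cn([C@H]2C[C@H](O)[C@@H](CO)O2)c(=O)[nH]c1=O` gives 78900 nM

Compound 2 stands level with compound 1 within the scatter, so the two numbers show no real spread yet. The next compound is compound 3 `C=Cc1cn([C@H]2C[C@H](O)[C@@H](CO)O2)c(=O)[nH]c1=O` and the change from compound 2 is vinyl in place of cyanosulfanyl on an aromatic carbon in short, vinyl in place of cyanosulfanyl on an aromatic carbon. Among the compounds with values here, only one measured step bears on this change. It is the step of a 1.2-fold higher number from compound 1 to compound 2 (0.09 log units; within the scatter) for cyanosulfanyl in place of 2-iodoethenyl on an aromatic carbon, and it lies within the scatter. Vinyl itself has not been measured in this series, and a single step is thin support, so the range is kept wide. No step beyond the scatter is expected in this assay and no direction can be assigned with confidence. The expected step is a 1.4-fold lower number from compound 2 to compound 3 (0.16 log units; within the scatter) on this estimate. The estimate for compound 3 is 55000 nM as the middle, 12000 nM as the lower end and 200000 nM as the upper end.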

Compound 3, half-maximal inhibitory concentration: 14200 nM
Estimate against measurement, compound 3: 3.9-fold (0.59 log units) above; low and high end bracket the measured number.
By their numbers in this assay, from the lowest: compound 3; then compounds 1 and 2 (each within the scatter of the next).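

In this assay the group on this aromatic carbon now matters: vinyl in place of cyanosulfanyl gives a 5.6-fold lower number from compound 2 to compound 3 (0.74 log units; beyond the scatter), and vinyl in place of 2-iodoethenyl gives a 4.5-fold lower number from compound 1 to compound 3 (0.65 log units; beyond the scatter), both modest in size, whereas the earlier step alone, a 1.2-fold higher number from compound 1 to compound 2 (0.09 log units; within the scatter), gave no sign that the position responds at all. The double bond outside the ring does not settle the number by itself, since compound 1 also carries one yet stands level with compound 2, and only compound 3 separates from the other two, with a group of carbon alone among its heavy atoms. No measurement among these data accounts for either step.

Still open, going by these compounds, is whether an ethyl or ethynyl group on this carbon would keep the lower number of compound 3, and whether a longer chain would return it to the level of compound 1 and compound 2. Within the data shown here, an amine or a carboxylic acid at the same place would show whether a group with heteroatoms can reach that lower number as well, a question that three compounds with only one such low value cannot settle.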